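Taking the hydroxy off compound 2

The compounds below may be only part of what the source reports. "The series", "measured", "known", "first", "only" and "open" are said of these compounds alone.

In a functional assay on A549 cells (Homo sapiens) for antiproliferative activity, read by MTT assay, with a stated time of 72 h (a higher number here means a weaker inhibitor, a lower number a stronger inhibitor), compound 1 (`Cc1nc(C)c(/C=C/C(=O)/C=C/c2ccc(O)cc2)nc1C`) gives 4010 nM and compound 2 (`COc1cc(/C=C/C(=O)/C=C/c2nc(C)c(C)nc2C)ccc1O`) gives 2190 nM. Among the measured compounds shown here, these are the only two numbers, and they lie within the scatter of each other, so compound 2 has no clear standing apart from compound 1.

Compound 3 (`COc1cccc(/C=C/C(=O)/C=C/c2nc(C)c(C)nc2C)c1`) differs from compound 2 by hydrogen in place of hydroxy on an aromatic carbon, ortho to a methoxy group and para to a large group: hydrogen in place of hydroxy on an aromatic carbon.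

For the measured compounds named here, the one measured step that bears on this is a 1.8-fold lower number from compound 1 to compound 2 (0.26 log units; within the scatter), for methoxy in place of hydrogen on an aromatic carbon. Going by the values given here, no measured step removes a hydroxy, so this guide is weak. In this assay, no change beyond the scatter is expected, and the expected step is a 1.4-fold higher number from compound 2 to compound 3 (0.14 log units; within the scatter). Compound 3 is estimated at 3000 nM, with an expected range of 1000 nM to 9000 nM.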

Compound 3, half-maximal inhibitory concentration: 3300 nM
Estimate against measurement, compound 3: 1.1-fold (0.04 log units) below; the measured number falls inside the stated range.
By their numbers in this assay, from the lowest: compounds 2, 3 and 1 (each within the scatter of the next).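

In this assay, among the compounds shown here, taking the hydroxy off gives a 1.5-fold higher number from compound 2 to compound 3 (0.18 log units; within the scatter), the first measured step at this place, para to a large group and ortho to a methoxy group. Earlier compounds all carried this hydroxy, whereas compound 3 shows that its loss, with 1 hydrogen-bond donor and 1 hydrogen-bond acceptor, produces no change beyond the scatter when the methoxy group stays in place. No measurement available here bears on the reason for this result.

Still open, going by these compounds, is whether an amine or a carboxylic acid in place of the hydroxy would give a step beyond the scatter at this place. Also open, on these data alone, is whether ethoxy, a longer chain, in place of the methoxy group would move the number in compound 3.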